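The source may report more compounds than this note shows. Statements on the series, on what has been measured and on what is new or still open speak of the compounds shown alone.

In a functional assay on HT-29 cells (Homo sapiens) for cytotoxicity, read by MTT assay (a lower number here means a stronger inhibitor, a higher number a weaker inhibitor), compound 1 `COc1ccc(OC)c(C(=O)/C=C/c2ccco2)c1` gives 24800 nM and compound 2 `COc1ccc(OC)c(C(=O)/C=C/c2ccc(C)o2)c1` gives 43000 nM. Among the compounds with values here, these are the only two numbers available, and they lie within the usual scatter of each other, so compound 2 cannot be separated from its single neighbour.

Compound 3 `COc1ccc(OC)c(C(=O)/C=C/c2ccc(C)s2)c1` has not yet been measured. It keeps the shared core and differs from compound 2 in one group: 5-methylthiophen-2-yl in place of 5-methylfuran-2-yl on a double-bonded chain carbon bound to a double-bonded chain carbon. The swap sits on a double-bonded chain carbon bound to a double-bonded chain carbon.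

Within the data shown here, no measured pair makes this same exchange, so the data offer no direct guide to it. Among the measured compounds shown here, the only measured step is methyl in place of hydrogen on an aromatic carbon, a 1.7-fold higher number from compound 1 to compound 2 (0.24 log units; within the scatter), and it is a different kind of change that gives only weak, indirect support. With so little evidence, no step beyond the scatter is expected in this assay, in either direction. The expected step is small: a 1.2-fold lower number from compound 2 to compound 3 (0.09 log units; within the scatter). The estimated value for compound 3 is 35000 nM, with an expected range from 14000 nM to 80000 nM.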

Compound 3, half-maximal inhibitory concentration: 1800 nM
Beside the measured number, compound 3's estimate is 19-fold (1.29 log units) above it; measured number below the stated range.
By their numbers in this assay, from the lowest: compound 3; then compounds 1 and 2 (each within the scatter of the next).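

Within the data shown here, compound 3 shows that the ring on a double-bonded chain carbon bound to a double-bonded chain carbon can strongly shift the result in this assay, which the earlier compounds could not reveal. Exchanging 5-methylfuran-2-yl for 5-methylthiophen-2-yl gives a 24-fold lower number from compound 2 to compound 3 (1.38 log units; beyond the scatter), even though the two groups match in every count shown apart from sulfur taking the place of oxygen in the five-membered aromatic ring. The comparison with the unmethylated furan-2-yl compound points the same way, with a 14-fold lower number from compound 1 to compound 3 (1.14 log units; beyond the scatter), so compound 3 stands clearly apart from both earlier compounds, and nothing available here explains why this exchange has so large an effect.

Going by these compounds, what remains open is whether the sulfur-containing ring is enough by itself or works only together with its methyl, a question that a plain thiophen-2-yl at this place would answer. On these data alone, it is also open how far the trend extends, for example to an ethyl group in place of the methyl, or to a phenyl or pyridine ring in place of the five-membered ring.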